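This account rests on a few compounds, and the source may have more. Where it says the series, first, only, none or still open, it means among the compounds named here.

Of the compounds shown here, two have so far been tested in a functional assay on PC-12 cells (Rattus norvegicus) for cytotoxicity, read by MTT assay, with stated times of 3 h and 2 h, tested at 1 uM; a lower number here means a weaker effect, a higher number a stronger effect of the compound at the concentration tested. Compound 1 `O=C(CCCCC1CCSS1)NCc1cn(CCCOc2ccc3cc(-c4ccc(Cl)cc4)c(=O)oc3c2)nn1` carries a 4-chlorophenyl group on the shared core together with a shorter connecting chain; in this assay compound 1 gives 49.3%. Compound 2 `O=C(CCCCC1CCSS1)NCc1cn(CCCCOc2ccc3ccc(=O)oc3c2)nn1` lacks that group and has a longer connecting chain; in this assay compound 2 gives 45.9%. Compound 2 thus stands at much the same level as compound 1, and the two numbers lie within the usual scatter of each other, so neither compound can be called the stronger.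

Compound 3 `O=C(CCCCC1CCSS1)NCc1cn(CCCCOc2ccc3cc(-c4ccc(Cl)cc4)c(=O)oc3c2)nn1` has not yet been measured. It keeps the longer chain of compound 2 and differs from it in one place: 4-chlorophenyl in place of hydrogen on an aromatic carbon. Within the data shown here, no pair of measured compounds differs by this change alone, so its effect cannot be read off directly. Compound 1 carries the same 4-chlorophenyl group, and its value 49.3% sits close to that of compound 2, which suggests the addition changes little here. The step of a number 2.1 percentage points higher from compound 2 to compound 3 (within the scatter) is therefore expected to stay within the scatter, with no clear direction. Compound 3 is estimated to give 48%, within a range from 38% to 58%.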

Compound 3, a percentage reported as activity, at one concentration (the size of the read-out at that concentration, not a potency): 46.2%
The estimate for compound 3 lay 1.8 percentage points above the measured number; the measured number falls inside the stated range.
By their numbers in this assay, from the lowest: compounds 2, 3 and 1 (each within the scatter of the next).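

Among these compounds, the pair of compound 2 and compound 3 is the first direct reading of this change: 4-chlorophenyl in place of hydrogen on an aromatic carbon, two atoms from the ring oxygen, with the longer connecting chain held the same. In this assay this single change amounts to a number 0.3 percentage points higher from compound 2 to compound 3 (within the scatter), so the two compounds cannot be told apart, even though the entering group brings 7 heavy atoms and a whole six-membered aromatic ring of carbon. No measurement is at hand that could explain this outcome.

The compounds shown leave open whether a different kind of group at this same position, such as an amine or a carboxylic acid, would produce a step beyond the scatter, and whether 4-chlorophenyl would behave the same way on another carbon of the shared core. Since the read-out comes from one concentration, they also leave open whether compound 2 and compound 3 would still match at higher or lower concentrations, as this single reading is not a measure of potency.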